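Swapping 2-methylphenyl for 4-chlorophenyl on the shared core

This account rests on a few compounds, and the source may have more. Where it says the series, first, only, none or still open, it means among the compounds named here.

Compound 1 `Cc1ccc(-c2cc(C(=O)N3CCC4(CC3)CC(=O)c3nn(C(C)(C)C)cc3O4)c3ccccc3n2)cc1`: 1440 nM
Compound 2 `Cc1ccccc1-c1cc(C(=O)N2CCC3(CC2)CC(=O)c2nn(C(C)(C)C)cc2O3)c2ccccc2n1`: > 10000 nM (a limit, not a number)

In a functional assay on HepG2 cells (Homo sapiens) for inhibition, read by MTT assay, with a stated time of 72 h (a lower number here means a stronger inhibitor, a higher number a weaker inhibitor), compound 2 gives > 10000 nM, which is a limit of the assay and not a number. The next compound, compound 3 `CC(C)(C)n1cc2c(n1)C(=O)CC1(CCN(C(=O)c3cc(-c4ccc(Cl)cc4)nc4ccccc34)CC1)O2`, has not yet been measured. It differs from compound 2 in a single place: 4-chlorophenyl in place of 2-methylphenyl on an aromatic carbon. The group sits on an aromatic carbon next to the ring nitrogen.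

For the measured compounds named here, only one measured step bears on this change: an at least 6.9-fold higher number from compound 1 to compound 2 (0.84 log units; beyond the scatter). That step brought in the same 2-methylphenyl that now leaves, in place of 4-methylphenyl. With 2-methylphenyl leaving and 4-chlorophenyl entering, much of that step is expected to reverse, toward the value of compound 1, 1440 nM. Going by the values given here, no measured compound carries 4-chlorophenyl, so the expectation stays loose. The expected move is toward a lower number, meaning a stronger inhibitor, and is estimated as an at least 5.0-fold lower number from compound 2 to compound 3 (0.69 log units; beyond the scatter). The estimate for compound 3 is 2000 nM, with an expected range of 600 nM to 8000 nM.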

Compound 3, half-maximal inhibitory concentration: 630 nM
The estimate for compound 3 lay 3.2-fold (0.50 log units) above the measured number; low and high end bracket the measured number.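

In this assay, the aromatic carbon next to the ring nitrogen is not closed to change: with 4-chlorophenyl in place of 2-methylphenyl there is an at least 15-fold lower number from compound 2 to compound 3 (1.20 log units; beyond the scatter), so the weak result seen with 2-methylphenyl does not extend to every substituted phenyl at this place. The new compound also goes past the earlier best, with a 2.3-fold lower number from compound 1 to compound 3 (0.36 log units; beyond the scatter), which shows that the group on the phenyl ring matters as well as where it sits, since chloro in place of methyl alone moves the number, whereas the earlier pair varied only the place of the methyl. The first of these steps gives only a minimum size, because compound 2 stands at a limit and not at a number: the limit of > 10000 nM in this assay, at which 1 of the 3 values shown sits.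

The compounds shown do not separate the effect of the group from the effect of its place on the phenyl ring, and 2-chlorophenyl would be needed to test whether the loss follows that place or the methyl. As far as these compounds go, whether fluoro, methoxy or a plain phenyl ring would match chloro also stays open.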